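Quinolin-2-yl in place of trifluoromethylphenyl on the dihydropyridine core

The source may report more compounds than this note shows. Statements on the series, on what has been measured and on what is new or still open speak of the compounds shown alone.

compound 1: `CC1=C(C(=O)OCC2CCN(C(=O)OC(C)(C)C)CC2)C(c2cccc([N+](=O)[O-])c2)C2=C(CC(C)(C)CC2=O)N1` gives > 10000 nM in an assay on HEK293 cells for inhibition of neurogenic locus notch homolog protein 1 (Homo sapiens), read by a luciferase reporter and resazurin assay, with a stated time of 16 h; a lower number here means a stronger inhibitor, a higher number a weaker inhibitor
compound 2: `CC1=C(C(=O)OCC2CCN(C(=O)OC(C)(C)C)CC2)C(c2cc(Cl)cc(Cl)c2)C2=C(CC(C)(C)CC2=O)N1` gives 640 nM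
compound 3: `CC1=C(C(=O)OCC2CCN(C(=O)OC(C)(C)C)CC2)C(c2cccc(C(F)(F)F)c2)C2=C(CC(C)(C)CC2=O)N1` gives 760 nM

The value of compound 1 is a limit of this assay, not a number (the limit of > 10000 nM in this assay, at which 1 of the 3 values shown sits). Compound 3 and compound 2 sit within the scatter of each other, a 1.2-fold higher number from compound 2 to compound 3 (0.07 log units; within the scatter). Compound 4, `CC1=C(C(=O)OCC2CCN(C(=O)OC(C)(C)C)CC2)C(c2ccc3ccccc3n2)C2=C(CC(C)(C)CC2=O)N1`, carries a quinolin-2-yl in place of 3-(trifluoromethyl)phenyl on a saturated ring carbon. The measured steps that touch this position are an at least 15-fold lower number from compound 1 to compound 2 (1.19 log units; beyond the scatter) and an at least 13-fold lower number from compound 1 to compound 3 (1.11 log units; beyond the scatter), both large, while a 1.2-fold higher number from compound 2 to compound 3 (0.07 log units; within the scatter) lies within the scatter. Going by the values given here, the aryl group thus can move the number strongly, and the quinolin-2-yl has no measured precedent here. Compound 4 is expected to give 2000 nM, within 400 nM to 10000 nM. This estimate corresponds to an expected 2.6-fold higher number from compound 3 to compound 4 (0.42 log units; beyond the scatter).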

Compound 4, half-maximal inhibitory concentration: 330 nM
Beside the measured number, compound 4's estimate is 6.1-fold (0.78 log units) above it; measured number outside the range, below it.
By their numbers in this assay, from the lowest: compounds 4, 2 and 3 (each within the scatter of the next, the first and the last beyond it). At a limit, above all of these: compound 1.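

On this saturated ring carbon the fused quinolin-2-yl, the first group shown with a ring nitrogen and a second aromatic ring, is accepted in this assay and gives a 2.3-fold lower number from compound 3 to compound 4 (0.36 log units; beyond the scatter) and also a 1.9-fold lower number from compound 2 to compound 4 (0.29 log units; within the scatter), so compound 4 cannot be separated from compound 2. The 3-nitrophenyl remains the outlier, with an at least 30-fold lower number from compound 1 to compound 4 (1.48 log units; beyond the scatter). The value of compound 1 is a limit and not a number: the limit of > 10000 nM in this assay, at which 1 of the 4 values shown sits.

The compounds shown leave open whether the ring nitrogen or the second ring carries this step. Naphthalen-2-yl, with carbon only, and pyridin-2-yl, with a single ring, would separate the two.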